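The source may report more compounds than this note shows. Statements on the series, on what has been measured and on what is new or still open speak of the compounds shown alone.

Measured compounds:
- Compound 1 `C[Se]c1nc([Se]C)c2cccnc2n1`; in a functional assay on HT-29 cells (Homo sapiens) for cytotoxicity, read by MTT assay, with a stated time of 72 h (on this read-out higher numbers stand for weaker inhibition of growth and lower numbers for stronger inhibition of growth), compound 1 gives "not determined" (no result reported).
- Compound 2 `CCCCC[Se]c1nc(NCc2ccc(SC)cc2)c2ccccc2n1`; in this assay compound 2 gives > 100000 nM, which is a limit of the assay and not a number.
- Compound 3 `CCCCC[Se]c1nc(NCc2ccccc2)c2ccccc2n1`; in this assay compound 3 gives > 100000 nM, likewise a limit.

Among the compounds with values here, compound 2 therefore stands at a limit only; the one other value with a number-like entry is also a limit, and the remaining entry carries no number. Within the data shown here, the one measured step, from compound 2 to compound 3 a step that the two limits leave unreadable from compound 2 to compound 3, changes hydrogen in place of methylsulfanyl on an aromatic carbon and tells nothing about size, both ends being limits.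

The next compound, compound 4 `CSc1ccc(CNc2nc([Se]C)nc3ccccc23)cc1`, differs from compound 2 by hydrogen in place of butyl on a saturated chain carbon bound to a selenium atom; cut one bond further out, the same change reads pentyl to methyl. Among the measured compounds shown here, no measured step touches this position, so the only bearing evidence is the limit of > 100000 nM in this assay, at which 2 of the 3 values shown sit, the limit at which two of the three values sit. No step beyond the scatter in this assay is expected in either direction. The step from compound 2 to compound 4 is expected to be a number no higher from compound 2 to compound 4 (the limit leaves the size open). Compound 4 is estimated at 100000 nM, with a range from 30000 nM to 300000 nM, and most likely the assay again reports only a limit.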

Compound 4, concentration for total growth inhibition: > 100000 nM
Compound 4 gave a limit, no number (the forecaster's own chance of this, stated with the estimate: 70%); the middle value sits exactly at the limit.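

No step can be read from compound 2 to compound 4, as both ends are limits of the assay and not numbers: the limit of > 100000 nM in this assay, at which 3 of the 4 values shown sit.

The compounds shown leave open whether any member of the series gives a number in this assay, and what size the changes from pentyl to methyl and from methylsulfanyl to hydrogen have.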